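A few compounds are considered here, and "the series" means these few. Any claim that something is new, unique, unknown or untested is made for them only; others in the source may bear on it.

In a functional assay on HL-60 cells (Homo sapiens) for cytotoxicity, read by CCK-8 assay, with a stated time of 24 h (on this read-out higher numbers stand for weaker inhibition and lower numbers for stronger inhibition), compound 1 `C=CC(=O)N1C(=O)CC(C)Sc2ccccc21` gives 199000 nM, and compound 2 `C=CC(=O)N1C(=O)CC(c2ccc(Cl)cc2)Sc2ccccc21` gives 95700 nM. Among the compounds with values here, on these two numbers compound 2 stands lowest, with compound 1 as its only neighbour, separated by a 2.1-fold lower number from compound 1 to compound 2 (0.32 log units; beyond the scatter), the sole measured step so far. Compound 3 `C=CC(=O)N1C(=O)CC(c2ccccc2Cl)Sc2ccccc21` is the next one to go into this assay. Its difference from compound 2 is 2-chlorophenyl in place of 4-chlorophenyl on a saturated ring carbon; the chlorine simply moves around the aromatic ring while the atoms stay the same. Within the data shown here, no measured step bears directly on such a shift of a substituent, since the only step in hand swapped a methyl for a whole 4-chlorophenyl group and gave a modest change. With no guide to this kind of change, a step of none beyond the scatter is expected, giving a 1.0-fold higher number from compound 2 to compound 3 (0.02 log units; within the scatter). Compound 3 is therefore estimated at 100000 nM, within a range from 40000 nM to 250000 nM.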

Compound 3, half-maximal inhibitory concentration: 91400 nM
Beside the measured number, compound 3's estimate is 1.1-fold (0.04 log units) above it, within the range that was stated.
By their numbers in this assay, from the lowest: compounds 3 and 2 (each within the scatter of the next); then compound 1.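

In this assay the chlorine changes place on the aromatic ring, 2-chlorophenyl in place of 4-chlorophenyl on the saturated ring carbon next to the ring sulfur, and this gives a 1.0-fold lower number from compound 2 to compound 3 (0.02 log units; within the scatter) with no readable difference between the two compounds. Replacing the methyl of compound 1 with 2-chlorophenyl gives a 2.2-fold lower number from compound 1 to compound 3 (0.34 log units; beyond the scatter) and thus the same direction as a 2.1-fold lower number from compound 1 to compound 2 (0.32 log units; beyond the scatter) so both chlorophenyl groups tested here read lower than methyl, whichever of these two places holds the chlorine. No evidence is available to explain these numbers.

As far as these compounds go, whether a phenyl ring without chlorine, or one carrying an amine or a carboxylic acid, would read differently at this carbon stays open. From the compounds shown here alone, all three compounds also carry the vinylcarbonyl group, so what a plain acetyl group there would do remains unknown.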